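Chain Branching Versus Halogen in a Small Oxindole Series

This account rests on a few compounds, and the source may have more. Where it says the series, first, only, none or still open, it means among the compounds named here.

Compound 1 `CC(C)CCC1(O)C(=O)Nc2ccc(Nc3ccc(F)cc3)cc21`: 16800 nM
Compound 2 `CCCCCCC1(O)C(=O)Nc2ccc(Nc3ccc(F)cc3)cc21`: 50700 nM
Compound 3 `CC(C)CCC1(O)C(=O)Nc2ccc(Nc3ccc(Cl)cc3)cc21`: 25000 nM

All three were measured in a functional assay on NCI-H460 cells (Homo sapiens) for antiproliferative activity, read by MTT assay, with a stated time of 48 h; on this read-out higher numbers stand for weaker inhibition and lower numbers for stronger inhibition. Compound 4 `CCCCCCC1(O)C(=O)Nc2ccc(Nc3ccc(Cl)cc3)cc21` has not yet been measured. It differs from compound 3 by butyl in place of isopropyl on a saturated chain carbon, two bonds along the chain from a saturated ring carbon. The same change is already on record once, from compound 1 to compound 2, as butyl in place of isopropyl on a saturated chain carbon, two bonds along the chain from a saturated ring carbon, where it gave a 3.0-fold higher number from compound 1 to compound 2 (0.48 log units; beyond the scatter). The two cores differ by chloro in place of fluoro on an aromatic carbon, a change that on its own gave a 1.5-fold higher number from compound 1 to compound 3 (0.17 log units; within the scatter). Among the compounds with values here, since the place of the chain change is described identically in both pairs, the step from compound 3 to compound 4 is expected to resemble the earlier one, because a 3.0-fold higher number from compound 1 to compound 2 (0.48 log units; beyond the scatter) is the only guide available. Compound 4 is therefore estimated at 75000 nM, a step of a 3.0-fold higher number from compound 3 to compound 4 (0.48 log units; beyond the scatter), with a plausible span from 35000 nM to 160000 nM.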

Compound 4, half-maximal inhibitory concentration: 30300 nM
For compound 4 the middle estimate is 2.5-fold (0.39 log units) above the measured one, outside the stated range (below it).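

In this assay, butyl in place of isopropyl gives a 1.2-fold higher number from compound 3 to compound 4 (0.08 log units; within the scatter), and chloro in place of fluoro gives a 1.7-fold lower number from compound 2 to compound 4 (0.22 log units; within the scatter), both within the scatter. The gap between the two chain steps does not establish that the effect depends on the core, nor does one pair of cores prove that the step carries over unchanged: the same change on two cores in this assay, a 3.0-fold higher number (0.48 log units; beyond the scatter) from compound 1 to compound 2 and a 1.2-fold higher number (0.08 log units; within the scatter) from compound 3 to compound 4, 2.5-fold (0.40 log units) apart, within the scatter of two such steps. The same limits apply to the halogen change: the same change on two cores in this assay, a 1.5-fold higher number (0.17 log units; within the scatter) from compound 1 to compound 3 and a 1.7-fold lower number (0.22 log units; within the scatter) from compound 2 to compound 4, 2.5-fold (0.40 log units) apart, within the scatter of two such steps.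

The compounds shown leave open how a longer chain such as octyl, or a chain ending in an amine, would compare. They also leave open whether bromo or methoxy in place of the halogen would follow these steps.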